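The compounds below may be only part of what the source reports. "The series", "measured", "known", "first", "only" and "open" are said of these compounds alone.

Compound 1 `Cc1ccc(/C=N/c2ccc(OCc3ccccc3)cc2)c(O)c1` was tested in a functional assay, with a stated time of 30 min (on this read-out higher numbers stand for weaker inhibition and lower numbers for stronger inhibition), where compound 1 reached only the limit of > 200000 nM. Compound 2 `Oc1ccc2ccccc2c1/C=N/c1ccc(OCc2ccccc2)cc1` likewise reached only the limit of > 200000 nM in this assay. Compound 1 therefore stands at the limit of > 200000 nM in this assay, at which 2 of the 2 values shown sit, with no number of its own. Compound 3 `Oc1ccc(F)cc1/C=N/c1ccc(OCc2ccccc2)cc1` carries 5-fluoro-2-hydroxyphenyl in place of 2-hydroxy-4-methylphenyl on a carbon with a double bond to nitrogen, that is, 5-fluoro-2-hydroxyphenyl in place of 2-hydroxy-4-methylphenyl on a carbon with a double bond to nitrogen. Going by the values given here, no measured step exists for this change, so from compound 1 to compound 3 in this assay an expected shift of a step that the limit leaves unreadable from compound 1 to compound 3 is given, none beyond the scatter. Compound 3 is estimated at 300000 nM, between 100000 nM and 1000000 nM.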

Compound 3, half-maximal inhibitory concentration: > 200000 nM
Compound 3 was reported as a limit (the forecaster's own chance of this, stated with the estimate: 85%); the middle value does not contradict the limit.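

In this assay, going by these compounds alone, compound 1 and compound 3 both stand only at a limit, so no step between them can be read: the limit of > 200000 nM in this assay, at which 3 of the 3 values shown sit. The compounds shown leave open how strongly any of them inhibits, and whether exchanging 2-hydroxy-4-methylphenyl for 5-fluoro-2-hydroxyphenyl changes inhibition at all.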